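Replacing the hydroxyphenyl of compound 1 with piperidinyl

The source may hold more compounds than are shown below. What is called first, only, known or untested is meant among the compounds shown, and "the series" means these compounds.

Compound 1 `Oc1ccc(-c2nc(-c3c[nH]c4ccccc34)co2)cc1` in a functional assay on MDA-MB-231 cells (Homo sapiens) for cytotoxicity, read by MTT assay, with a stated time of 48 h (on this read-out lower numbers stand for stronger inhibition and higher numbers for weaker inhibition), gives 103000 nM, level with compound 3 `COc1cc(-c2nc(-c3c[nH]c4ccccc34)co2)ccc1O` at 103000 nM and indistinguishable from compound 2 `COc1ccc(-c2nc(-c3c[nH]c4ccccc34)co2)cc1` at 108000 nM; all three sit together. The two known steps, a 1.0-fold higher number from compound 1 to compound 2 (0.02 log units; within the scatter) and no change at the digits printed from compound 1 to compound 3 (within the scatter), are both within the scatter. Compound 4 `c1ccc2c(-c3coc(C4CCNCC4)n3)c[nH]c2c1` differs from compound 1 by piperidin-4-yl in place of 4-hydroxyphenyl on an aromatic carbon. Among the compounds with values here, no measured step touches this position; the known steps alter only the 4-hydroxyphenyl and neither moved the number, so they give no direction for the new change. The expected step is therefore none beyond the scatter, with a wide range for lack of precedent: compound 4 is estimated at 100000 nM (35000 nM to 300000 nM), meaning a 1.0-fold lower number from compound 1 to compound 4 (0.01 log units; within the scatter).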

Compound 4, half-maximal inhibitory concentration: 528000 nM
Estimate against measurement, compound 4: 5.3-fold (0.72 log units) below; measured number above the stated range.
By their numbers in this assay, from the lowest: compounds 1, 3 and 2 (each within the scatter of the next); then compound 4.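

The position on the aromatic carbon of the five-membered ring responds where the earlier changes within the 4-hydroxyphenyl did not: in this assay, piperidin-4-yl in place of 4-hydroxyphenyl gives a 5.1-fold higher number from compound 1 to compound 4 (0.71 log units; beyond the scatter) and inhibition weakens. This is the only step shown that lies beyond the scatter, although both groups count the same hydrogen-bond donors and acceptors. Nothing available accounts for the step.

Still open, on these data alone, is whether the ring nitrogen or the loss of the aromatic ring drives this step. Cyclohexyl and unsubstituted phenyl at this place would separate the two.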